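Cytotoxicity readings: from compound 3 to compound 4

A few compounds are considered here, and "the series" means these few. Any claim that something is new, unique, unknown or untested is made for them only; others in the source may bear on it.

For the measured compounds named here, compound 1 `COc1ccc(/C=C/C(=O)NCCCC(C)Nc2cc(OC)cc3cccnc23)cc1` and compound 2 `COc1cc(NC(C)CCCNC(=O)/C=C/c2ccc(OC)c(OC)c2)c2ncccc2c1` are the only members with a reading in an ADME assay on L6 cells (Rattus norvegicus) for cytotoxicity, read by resazurin assay, with a stated time of 70 h; on this read-out lower numbers stand for stronger inhibition and higher numbers for weaker inhibition. In this assay compound 1 returns only a limit, > 240000 nM. In this assay compound 2 likewise returns only a limit, > 220000 nM. Going by the values given here, the single change between them, methoxy in place of hydrogen on an aromatic carbon, gives a step that the two limits leave unreadable from compound 1 to compound 2. Compound 3 `COc1cc(NC(C)CCCNC(=O)NC2CCCC2)c2ncccc2c1` shares the core, and in this assay compound 3 has "not determined" (no result reported). Where it stands can only be placed against the limit of > 220000 nM in this assay, at which 1 of the 3 values shown sits, and (the limit of > 240000 nM in this assay, at which 1 of the 3 values shown sits), both of which are limits rather than numbers. Compound 4 `COc1cc(NC(C)CCCNC(=O)NNC(=O)N(CCO)CCO)c2ncccc2c1` differs from compound 3 by (bis(2-hydroxyethyl)carbamoyl)amino in place of cyclopentyl on an amide-type nitrogen. Among the compounds with values here, no measured step covers this change, and the only measured step is unreadable, so no direction beyond the scatter can be expected in this assay. Compound 4 is therefore expected to sit at a limit as well, estimated at 230000 nM with a range of 100000 nM to 400000 nM.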

Compound 4, half-maximal inhibitory concentration: 178000 nM
The estimate for compound 4 lay 1.3-fold (0.11 log units) above the measured number, and the stated range covers the measured number.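

No step can be read from compound 3 to compound 4 in this assay: compound 3 has "not determined" (no result reported), while compound 4 gives 178000 nM. The compounds shown leave open what (bis(2-hydroxyethyl)carbamoyl)amino in place of cyclopentyl does to this reading. No available evidence bears on this result.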